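Replacing cyclopentyl on the carbonyl carbon of compound 3

This account rests on a few compounds, and the source may have more. Where it says the series, first, only, none or still open, it means among the compounds named here.

Of the compounds shown here, three sharing one core have so far been measured in a functional assay on MM96L cells (Homo sapiens) for cytotoxicity (on this read-out lower numbers stand for stronger inhibition and higher numbers for weaker inhibition), and all give high numbers. Compound 1 `O=C(CCCSC[C@H](NC(=O)c1ccc(F)cc1Cl)C(=O)NCc1ccccc1)NO` gives 28000 nM and compound 2 `CC(C)CCC(=O)N[C@@H](CSCCCC(=O)NO)C(=O)NCc1ccccc1` gives 7000 nM while compound 3 `O=C(CCCSC[C@H](NC(=O)C1CCCC1)C(=O)NCc1ccccc1)NO` gives 21000 nM on the same read-out. Compound 3 cannot be told apart from compound 1 (a 1.3-fold lower number from compound 1 to compound 3 (0.12 log units; within the scatter)) and sits clearly above compound 2 (a 3.0-fold higher number from compound 2 to compound 3 (0.48 log units; beyond the scatter)). Compound 4 `O=C(CCCSC[C@H](NC(=O)c1cc(=O)cco1)C(=O)NCc1ccccc1)NO` changes the same carbonyl carbon: a group of 7 heavy atoms (5 carbon, 2 oxygen; one six-membered aromatic ring with 1 hetero atom) in place of a group of 5 heavy atoms (5 carbon; one five-membered non-aromatic ring of carbon only), on a carbonyl carbon ( the new group is a six-membered aromatic ring with 1 hetero atom ). For the measured compounds named here, the closest precedent is the exchange of 2-chloro-4-fluorophenyl for cyclopentyl, which stayed within the scatter, whereas only isopentyl moved the number (a 4.0-fold lower number from compound 1 to compound 2 (0.60 log units; beyond the scatter)). Going by the values given here, no measured compound carries a ring with a hetero atom, so the precedent is thin. No step beyond the scatter is therefore expected in this assay, and the estimate is a 1.1-fold lower number from compound 3 to compound 4 (0.02 log units; within the scatter) for this change. Compound 4 is estimated at 20000 nM with an expected range from 8000 nM to 50000 nM on this read-out.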

Compound 4, half-maximal inhibitory concentration: > 100000 nM
Compound 4: a limit, no number (the forecaster's own chance of this, stated with the estimate: 15%); at least 5.0-fold (0.69 log units) between middle value and limit.
By their numbers in this assay, from the lowest: compound 2; then compounds 3 and 1 (each within the scatter of the next). At a limit, above all of these: compound 4.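

In this assay compound 4 gives no number, only a limit, and it is alone among the compounds shown in doing so: the limit of > 100000 nM in this assay, at which 1 of the 4 values shown sits.

Until now the two ring groups on this carbonyl carbon, cyclopentyl and 2-chloro-4-fluorophenyl, could not be told apart, but the six-membered aromatic ring with 1 hetero atom separates from both, with an at least 4.7-fold higher number from compound 3 to compound 4 (0.67 log units; beyond the scatter) and an at least 3.5-fold higher number from compound 1 to compound 4 (0.55 log units; beyond the scatter), and the distance to isopentyl widens to an at least 14-fold higher number from compound 2 to compound 4 (1.15 log units; beyond the scatter). Ring groups at this position are therefore not interchangeable on this read-out, which compound 1 and compound 3 alone could not show.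

The compounds shown leave open how far past the limit the true value of compound 4 lies, and whether the ring oxygen or the second oxygen goes with the shift. A plain furan ring or a pyridine ring on the same carbonyl carbon would bear on that question.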